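A few compounds are considered here, and "the series" means these few. Any claim that something is new, unique, unknown or untested is made for them only; others in the source may bear on it.

Measured so far in an assay on isolated protein with Bile acid receptor (Homo sapiens) as the target; a higher number here means that more compound is needed for the effect, a lower number that less compound is needed:
compound 1, `COC(=O)/C=C/c1cccc(N(Cc2ccc(/C=C/c3c(Cl)cccc3Cl)cc2)C(=O)C(C)C)c1`: 195 nM
compound 2, `CCOc1cccc(-c2ccc(CN(C(=O)C(C)C)c3cccc(/C=C/C(=O)OC)c3)cc2)c1`: 173 nM
compound 3, `COC(=O)/C=C/c1cccc(N(Cc2ccc(-c3ccc(OC(F)(F)F)cc3)cc2)C(=O)C(C)C)c1`: 219 nM

Compound 3 has the highest of the three numbers, but the steps of a 1.1-fold higher number from compound 1 to compound 3 (0.05 log units; within the scatter) and a 1.3-fold higher number from compound 2 to compound 3 (0.10 log units; within the scatter) both lie within the scatter, so the three compounds are not separable on these data. Compound 4, `COC(=O)/C=C/c1cccc(N(Cc2ccc(/C=C/c3cccc(Cl)c3)cc2)C(=O)C(C)C)c1`, differs from compound 3 by 2-(3-chlorophenyl)ethenyl in place of 4-(trifluoromethoxy)phenyl on an aromatic carbon. Among the compounds with values here, the steps that bear on this change are a 1.1-fold lower number from compound 1 to compound 2 (0.05 log units; within the scatter), a 1.1-fold higher number from compound 1 to compound 3 (0.05 log units; within the scatter) and a 1.3-fold higher number from compound 2 to compound 3 (0.10 log units; within the scatter): three different groups on the same aromatic carbon of the shared core, all giving numbers within the scatter of each other. Compound 1 carries a 2-(2,6-dichlorophenyl)ethenyl group, the closest analogue of the incoming 2-(3-chlorophenyl)ethenyl group, and gives 195 nM. No step beyond the scatter is therefore expected from compound 3 to compound 4 in this assay, the expected change being a 1.1-fold lower number from compound 3 to compound 4 (0.04 log units; within the scatter). Compound 4 is estimated at 200 nM, with a range from 100 nM to 400 nM.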

Compound 4, half-maximal effective concentration: 164 nM
Estimate against measurement, compound 4: 1.2-fold (0.09 log units) above, and the stated range covers the measured number.
By their numbers in this assay, from the lowest: compounds 4, 2, 1 and 3 (each within the scatter of the next).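

In this assay a fourth group, 2-(3-chlorophenyl)ethenyl, now sits on this aromatic carbon para to a large group, and its step from the 4-(trifluoromethoxy)phenyl group is a 1.3-fold lower number from compound 3 to compound 4 (0.13 log units; within the scatter), with a 1.1-fold lower number from compound 2 to compound 4 (0.02 log units; within the scatter) against the 3-ethoxyphenyl group. The comparison with compound 1 adds a change on the outer ring of the ethenyl group, 3-chlorophenyl in place of 2,6-dichlorophenyl, and this too gives only a 1.2-fold lower number from compound 1 to compound 4 (0.08 log units; within the scatter), so neither the direct aryl groups, the ethenyl-linked groups, nor the chlorine pattern separate on these numbers. No measurement is available that bears on why these groups give such similar numbers.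

On these data alone, all four groups at this carbon carry a six-membered aromatic ring, so the effect of a group without one, such as an amine or a plain alkyl chain, remains open. The methyl ester and the amide are the same throughout, leaving open what a carboxylic acid in place of that ester would give.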